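Shortening the ester chain in a pyridylmethyl imine series

The source may hold more compounds than are shown below. What is called first, only, known or untested is meant among the compounds shown, and "the series" means these compounds.

Three esters share one core, a phenyl imine of a pyridylmethyl amine. Compound 1 is `CCCCCCCCCCCCCC(=O)Oc1ccc(/C=N/Cc2cccnc2)cc1`, compound 2 is `CCCCCCCCCCCC(=O)Oc1ccc(/C=N/Cc2cccnc2)cc1` and compound 3 is `CCCCCCCC(=O)Oc1ccc(/C=N/Cc2cccnc2)cc1`. In a functional assay on MCF7 cells (Homo sapiens) for cytotoxicity (a higher number here means a weaker inhibitor, a lower number a stronger inhibitor), compound 1 is reported as "not active" (no number reported). In this assay compound 2 gives 17600 nM. Among the compounds with values here, compound 2 thus holds the only number reported here, with compound 1 returning no number at all, so no measured step can be stated.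

Compound 3 differs from compound 2 by hydrogen in place of butyl on a saturated chain carbon, seven bonds along the chain from a carbonyl carbon. The chain becomes shorter, moving away from the longer chain of compound 1, which gave no number.

Compound 3 is therefore expected to be somewhat stronger in this assay than compound 2, and the estimated step of a 2.0-fold lower number from compound 2 to compound 3 (0.29 log units; within the scatter) is modest, barely beyond the usual scatter. For compound 3 the estimate in this assay is 9000 nM, expected to fall between 3500 nM and 30000 nM.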

Compound 3, half-maximal inhibitory concentration: 12000 nM
Compound 3: middle estimate off by 1.3-fold (0.12 log units), on the low side; low and high end bracket the measured number.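

In this assay, hydrogen in place of butyl on a saturated chain carbon, seven bonds along the chain from a carbonyl carbon, gives a 1.5-fold lower number from compound 2 to compound 3 (0.17 log units; within the scatter) and so leaves the two esters indistinguishable. Within the data shown here, this is the first measured comparison at this position, and it shows that removing those four chain carbons does not separate compound 3 from compound 2 beyond the scatter, while compound 1, with the longer chain, gives "not active" (no number reported) and any step involving it cannot be read. Nothing available here bears on why these esters read as they do.

Going by these compounds, it remains open whether a much shorter chain, such as an acetyl ester, would give a number that stands clear of those of compound 2 and compound 3. On these data alone, it is equally open whether an amide in place of the ester, or a terminal amine or carboxylic acid on the chain, would leave the reading in this assay as it stands or move it beyond the scatter.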